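One ring exchanged on compound 2

The compounds below may be only part of what the source reports. "The series", "measured", "known", "first", "only" and "open" are said of these compounds alone.

Three related compounds have been measured so far. In a physicochemical assay for lipophilicity, read by HPLC, at pH 7.5 (a higher number here means a more lipophilic compound, a lower number a more polar compound), compound 1 `N#Cc1c(-c2ccc(Br)cc2)nc2cnccc2c1NCC(N)=O` gives 1.9 and compound 2 `CC[C@@H](Nc1c(C#N)c(-c2ccc(-c3ncccc3C)cc2)nc2cnccc12)C(N)=O` gives 2 so these two lie within the usual scatter of each other. Compound 3 `CCOc1ccccc1-c1ccc(-c2nc3cncc(Cl)c3c(N[C@H](CC)C(N)=O)c2C#N)cc1` reaches 3.7 in the same measurement, which places it beyond the scatter above compound 2. Compound 2 therefore stands level with compound 1 and well under compound 3.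

Compound 4 `CC[C@@H](Nc1c(C#N)c(-c2ccc(-c3cccc(Cl)c3F)cc2)nc2cnccc12)C(N)=O` differs from compound 2 in one place. The change 3-chloro-2-fluorophenyl in place of 3-methylpyridin-2-yl on an aromatic carbon puts 3-chloro-2-fluorophenyl in place of 3-methylpyridin-2-yl on an aromatic carbon. The entering ring is of carbon only, while the leaving ring holds a nitrogen.

Among the measured compounds shown here, no measured pair differs in just one place, so no direct step is available as a guide. The nearest hint is compound 3 at 3.7 as it carries a ring of carbon only where compound 2 has its 3-methylpyridin-2-yl, although it also differs from compound 2 elsewhere. An upward step is therefore expected, estimated at a number 1.20 log units higher from compound 2 to compound 4 (beyond the scatter) and so beyond the scatter. For compound 4 the expected value is 3.2 with an estimated range from 2.6 to 3.8 in this assay once it is measured.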

Compound 4, distribution coefficient: 3.1
Compound 4: middle estimate off by 0.10 log units, on the high side; the range from low to high includes it.
By their numbers in this assay, from the lowest: compounds 1 and 2 (each within the scatter of the next); then compound 4; then compound 3.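

In this assay, among the compounds shown here, the exchange of 3-methylpyridin-2-yl for 3-chloro-2-fluorophenyl gives the first reading of a change made in one place alone: the number moves a number 1.10 log units higher from compound 2 to compound 4 (beyond the scatter) with the rest of the molecule untouched. For the compounds shown here, this shows that the group on this aromatic carbon, para to a large group, can by itself shift the reading by a large amount, which the earlier compounds could not show while they differed in several places at once. The exchange replaces a ring holding one nitrogen with a ring of carbon only that carries a fluorine and a chlorine, but nothing measured here accounts for the size of the step.

The compounds shown leave open how much of the step belongs to the loss of the ring nitrogen and how much to the arrival of the chlorine and the fluorine, and an unsubstituted phenyl ring at this place would help to separate those parts. Also unanswered is how the reading would respond to an amine or a carboxylic acid carried on the ring at this place.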